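A few compounds are considered here, and "the series" means these few. Any claim that something is new, unique, unknown or untested is made for them only; others in the source may bear on it.

Three compounds share one core, a sulfonamide-linked piperidine carrying a sulfonyl-bearing aryl group, and differ only in what sits on the piperidine nitrogen. Compound 1 `O=C(c1ccc(C(F)(F)F)cc1)N1CCC(NS(=O)(=O)c2cc(S(=O)(=O)c3ccccc3)ccc2C(F)(F)F)CC1` gives 400 nM in an assay on isolated protein for displacement of a labelled ligand from secreted frizzled-related protein 1 (Homo sapiens), read by fluorescence polarization, with a stated time of 30 min; on this read-out lower numbers stand for stronger inhibition and higher numbers for weaker inhibition. Compound 2 `O=C(O)c1ccc(N2CCC(NS(=O)(=O)c3cc(S(=O)(=O)c4ccccc4)ccc3C(F)(F)F)CC2)cc1` gives 120 nM in this assay, a change of a 3.3-fold lower number from compound 1 to compound 2 (0.52 log units; beyond the scatter). Compound 3 `CC(C)(C)OC(=O)N1CC[C@@H](C(=O)N2CCC(NS(=O)(=O)c3cc(S(=O)(=O)c4ccccc4)ccc3C(F)(F)F)CC2)C1` gives 50 nM in this assay, a change of an 8.0-fold lower number from compound 1 to compound 3 (0.90 log units; beyond the scatter); compound 3 thus stands lowest of the three numbers, with compound 2 nearest and compound 1 furthest.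

Compound 4 `O=C(C1CCNCC1)N1CCC(NS(=O)(=O)c2cc(S(=O)(=O)c3ccccc3)ccc2C(F)(F)F)CC1` is not yet measured. It differs from compound 3 in one place: piperidin-4-yl in place of 1-(tert-butoxycarbonyl)pyrrolidin-3-yl on a carbonyl carbon. Among the measured compounds shown here, both measured steps touch this same region on the piperidine nitrogen, and both moved the number down by a modest amount, yet neither removes a tert-butoxycarbonyl group or changes ring size, so no measured step directly covers this change. The expectation for compound 4 is a step of a 2.0-fold higher number from compound 3 to compound 4 (0.30 log units; within the scatter) in this assay, most likely within or just beyond the scatter. Compound 4 is therefore estimated at 100 nM, with a range from 30 nM to 400 nM.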

Compound 4, half-maximal inhibitory concentration in the secreted frizzled-related protein 1 assay: 120 nM
Compound 4: middle estimate off by 1.2-fold (0.08 log units), on the low side; low and high end bracket the measured number.
By their numbers in the secreted frizzled-related protein 1 assay, from the lowest: compound 3; then compounds 2 and 4 (each within the scatter of the next); then compound 1.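

On the carbonyl carbon, the aromatic ring is not needed for a lower number: in the secreted frizzled-related protein 1 assay, piperidin-4-yl in place of 4-(trifluoromethyl)phenyl gives a 3.3-fold lower number from compound 1 to compound 4 (0.52 log units; beyond the scatter) and losing 1-(tert-butoxycarbonyl)pyrrolidin-3-yl costs only a 2.4-fold higher number from compound 3 to compound 4 (0.38 log units; beyond the scatter) on the same read-out. Exchanging 4-carboxyphenyl for (piperidin-4-yl)carbonyl on the ring amine nitrogen gives no change at the digits printed from compound 2 to compound 4 (within the scatter) in this assay, so these two quite different groups read alike. The step from the larger group to piperidin-4-yl also raises the number in a physicochemical assay for solubility (on this read-out lower numbers stand for lower solubility and higher numbers for higher solubility), the read-out for solubility, where compound 3 gives 12500 nM and compound 4 gives 100000 nM: the measured solubility of compound 3, 12500 nM, and of compound 4, 100000 nM, an 8.0-fold higher number (0.90 log units; beyond the scatter).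

This one step drops the tert-butoxycarbonyl group and changes ring size together, so the compounds shown cannot separate the two. An unprotected pyrrolidin-3-yl, or a piperidin-4-yl carrying tert-butoxycarbonyl, would be needed to tell them apart.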